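This account rests on a few compounds, and the source may have more. Where it says the series, first, only, none or still open, it means among the compounds named here.

Measured so far in a functional assay on DU-145 cells (Homo sapiens) for cytotoxicity, read by sulforhodamine B assay, with a stated time of 48 h; on this read-out lower numbers stand for stronger inhibition of growth and higher numbers for weaker inhibition of growth:
Compound 1 `N#Cc1ccc(Nc2nc(Oc3ccnc4ccccc34)nc(N3CCN(c4cccc(C(F)(F)F)c4)CC3)n2)cc1C(F)(F)F` gives 74100 nM.
Compound 2 `N#Cc1ccc(Nc2nc(Oc3ccnc4ccccc34)nc(N3CCN(c4ncccn4)CC3)n2)cc1C(F)(F)F` gives only an assay limit, > 100000 nM.
Compound 3 `N#Cc1ccc(Nc2nc(Oc3ccnc4ccccc34)nc(N3CCN(Cc4ccccc4)CC3)n2)cc1C(F)(F)F` gives only an assay limit, > 100000 nM.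

Compound 3 thus stands at the limit of this assay, with no number of its own; two of the three values shown sit there (the limit of > 100000 nM in this assay, at which 2 of the 3 values shown sit). Compound 4 `N#Cc1ccc(Nc2nc(Oc3ccnc4ccccc34)nc(N3CCN(c4ccccc4F)CC3)n2)cc1C(F)(F)F` differs from compound 3 by 2-fluorophenyl in place of benzyl on an amine nitrogen in a ring. Steps that bear on this change: an at least 1.3-fold higher number from compound 1 to compound 3 (0.13 log units; that floor lies within the scatter) and an at least 1.3-fold higher number from compound 1 to compound 2 (0.13 log units; that floor lies within the scatter), both at floors that lie within the scatter, and a step that the two limits leave unreadable from compound 2 to compound 3. None of them resolves a direction beyond the scatter, so no step beyond the scatter is expected from compound 3 to compound 4, an at least 1.1-fold lower number from compound 3 to compound 4 (0.04 log units; that floor lies within the scatter). Compound 4 is estimated at 90000 nM, with a range from 40000 nM to 200000 nM, and a limit is the likelier report.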

Compound 4, concentration for total growth inhibition: > 100000 nM
Compound 4: only a limit was reported; the forecaster's own chance of this, stated with the estimate: 60%; middle value at least 1.1-fold (0.04 log units) from the limit.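

In this assay compound 4 gives only a limit, so 2-fluorophenyl on this amine nitrogen in a ring joins pyrimidin-2-yl and benzyl there: the limit of > 100000 nM in this assay, at which 3 of the 4 values shown sit. The steps from compound 2 and from compound 3 to compound 4 join two limits and cannot be read. Going by these compounds alone, the one readable step is an at least 1.3-fold higher number from compound 1 to compound 4 (0.13 log units; that floor lies within the scatter), so 2-fluorophenyl and 3-(trifluoromethyl)phenyl are not separated beyond the scatter.

As far as these compounds go, what a methyl, an acetyl or a longer chain carrying an amine would give on this ring nitrogen stays open. Also open, from the compounds shown here alone, is whether replacing the nitrile on the shared core would bring values off the limit.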